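The source may hold more compounds than are shown below. What is called first, only, known or untested is meant among the compounds shown, and "the series" means these compounds.

Compound 1 `OC[C@H]1O[C@@H](n2cnc3c(NCc4ccccc4Cl)ncnc32)[C@H](O)[C@@H]1O`, compound 2 `Cc1ccc(CNc2ncnc3c2ncn3[C@@H]2O[C@H](CO)[C@@H](O)[C@H]2O)cc1` and compound 3 `COc1cccc(CNc2ncnc3c2ncn3[C@@H]2O[C@H](CO)[C@@H](O)[C@H]2O)c1` share one core, which compound 4 `OC[C@H]1O[C@@H](n2cnc3c(NCc4ccc(Cl)c(Cl)c4)ncnc32)[C@H](O)[C@@H]1O` keeps. In a functional assay on B16 cells (Mus musculus) for antiproliferative activity, with a stated time of 72 h (a lower number here means a stronger inhibitor, a higher number a weaker inhibitor), compound 3 gives > 166000 nM, which is a limit and not a number. Compound 1 gives > 166000 nM, also a limit. For compound 2 the entry reads "not determined" (no result reported). Compound 3 thus stands at the limit of > 166000 nM in this assay, at which 2 of the 3 values shown sit. Compound 4 carries 3,4-dichlorophenyl in place of 3-methoxyphenyl on a saturated chain carbon bound to a nitrogen on an aromatic ring. Among the measured compounds shown here, the only measured step that bears on this change, a step that the two limits leave unreadable from compound 1 to compound 3, has no readable size, so it offers neither a size nor a direction to carry over. The expected step is therefore small, with no firm direction: an at least 1.1-fold lower number from compound 3 to compound 4 (0.04 log units; that floor lies within the scatter). For compound 4 the estimated value is 150000 nM, with an expected range of 50000 nM to 300000 nM.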

Compound 4, half-maximal inhibitory concentration: > 166000 nM
Compound 4 was reported as a limit (the forecaster's own chance of this, stated with the estimate: 60%); at least 1.1-fold (0.04 log units) between middle value and limit.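

No step can be read from compound 3 to compound 4 or from compound 1 to compound 4 in this assay, since all three values are limits: the limit of > 166000 nM in this assay, at which 3 of the 4 values shown sit.

Going by these compounds, whether any of these groups on the shared core changes the result, and how compound 1, compound 3 and compound 4 rank, stays open.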